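The source may hold more compounds than are shown below. What is called first, only, known or untested is meant among the compounds shown, and "the series" means these compounds.

In a functional assay on OVCAR-3 cells (Homo sapiens) for inhibition, read by colorimetric assay and sulforhodamine B assay, with a stated time of 48 h (a lower number here means a stronger inhibitor of growth, a higher number a weaker inhibitor of growth), compound 1 `CCCCCCCCCCCC[C@@H](O)[C@H]1CC[C@H]([C@H](O)CCCCCCCCCCNC(=O)c2ccco2)O1` gives 100000 nM and compound 2 `CCCCCCCCCCCC[C@@H](O)[C@H]1CC[C@H]([C@H](O)CCCCCCCCCCNC(=O)c2cncs2)O1` gives 100000 nM at the digits shown, so the two stand level. Compound 3 `CCCCCCCCCCCC[C@@H](O)[C@H]1CC[C@H]([C@H](O)CCCCCCCCCCNC(=O)c2ccnn2C)O1` carries 1-methyl-1H-pyrazol-5-yl in place of 1,3-thiazol-5-yl on a carbonyl carbon, the difference being 1-methyl-1H-pyrazol-5-yl in place of 1,3-thiazol-5-yl on a carbonyl carbon in all. Among the compounds with values here, the one measured step at this place shows no change at the digits printed from compound 1 to compound 2 (within the scatter) and bears directly on this change. No shift beyond the scatter is therefore expected in this assay and the estimated step is no change at the digits printed from compound 2 to compound 3 (within the scatter) here. Compound 3 is estimated at 100000 nM within a range of 40000 nM to 130000 nM in this measurement.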

Compound 3, concentration for 50% growth inhibition: 77600 nM
For compound 3 the middle estimate is 1.3-fold (0.11 log units) above the measured one; the measured number falls inside the stated range.
By their numbers in this assay, from the lowest: compounds 3, 1 and 2 (each within the scatter of the next).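

In this assay, 1-methyl-1H-pyrazol-5-yl on the carbonyl carbon, although it has one more heavy atom than 1,3-thiazol-5-yl and carries a methyl group, gives a number within the scatter of both earlier compounds (a 1.3-fold lower number from compound 2 to compound 3 (0.11 log units; within the scatter); a 1.3-fold lower number from compound 1 to compound 3 (0.11 log units; within the scatter)). This position has now taken three different rings with no shift beyond the scatter. Nothing measured here accounts for that. Going by these compounds, whether a phenyl ring, a pyridine ring or an amine at this place would move the number stays open, as does any effect of a shorter chain.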